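Ester-to-acid change at the amide side chain

The source may hold more compounds than are shown below. What is called first, only, known or untested is meant among the compounds shown, and "the series" means these compounds.

The three measured compounds share one core. Compound 1 `CCn1c(C(=O)NCc2ccc(OC)cc2)ccc1C(CC)(CC)c1ccc(C#CC(O)(CC)CC)c(C)c1` and compound 2 `CCCCC(=O)c1ccc(C(CC)(CC)c2ccc(C#CC(O)(CC)CC)c(C)c2)n1CC` differ at a carbonyl carbon. In an assay on cells for agonist activity at vitamin D3 receptor (Homo sapiens), read by microscopy (a lower number here means that less compound is needed, a higher number that more compound is needed for the effect), compound 1 gives > 50 nM, which is a limit of the assay and not a number. Compound 2 likewise gives only a limit, > 50 nM. The step between them, a step that the two limits leave unreadable from compound 1 to compound 2, cannot be read because both values sit at the limit of > 50 nM in this assay, at which 2 of the 3 values shown sit. For the measured compounds named here, compound 3 `CCn1cc(C(CC)(CC)c2ccc(C#CC(O)(CC)CC)c(C)c2)cc1C(=O)NCC(=O)OC` gives 288 nM, the only number among the three values. Compound 3 therefore cannot be ranked against compound 1 or compound 2.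

Compound 4 `CCn1cc(C(CC)(CC)c2ccc(C#CC(O)(CC)CC)c(C)c2)cc1C(=O)NCCC(=O)O` differs from compound 3 only as carboxymethyl in place of methoxycarbonyl on a saturated chain carbon bound to an amide-type nitrogen. Going by the values given here, no measured step bears on this change: the single step in the set is unreadable and concerns another place on the core. The two compounds hold the same atoms, joined differently, and nothing in the data points in either direction. No shift beyond the usual scatter is therefore expected, and the estimated step is a 1.0-fold higher number from compound 3 to compound 4 (0.02 log units; within the scatter). Compound 4 is expected at about 300 nM, within 100 nM to 1000 nM, a wide range that reflects an estimate resting on a single number.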

Compound 4, half-maximal effective concentration: > 50 nM
Compound 4: no number, only a limit (the forecaster's own chance of this, stated with the estimate: 30%); the middle value does not contradict the limit.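

In this assay compound 4 gives > 50 nM, which is a limit of the assay and not a number. No step can be read between compound 3 and compound 4 because this value is only a limit: the limit of > 50 nM in this assay, at which 3 of the 4 values shown sit.

On these data alone, whether carboxymethyl in place of methoxycarbonyl on a saturated chain carbon bound to an amide-type nitrogen shifts the value, in which direction and by how much, remains open.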